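The source may report more compounds than this note shows. Statements on the series, on what has been measured and on what is new or still open speak of the compounds shown alone.

Compound 3 `C=CC(=O)Nc1cccc(NC(=O)CSc2nc(Nc3ccccc3)c3ccccc3n2)c1` gives 7310 nM in a functional assay on MGC-803 cells (Homo sapiens) for inhibition, read by MTT assay, with a stated time of 72 h (on this read-out higher numbers stand for weaker inhibition and lower numbers for stronger inhibition), the lowest of the three numbers. Compound 1 `O=C(CSc1nc(Nc2ccccc2)c2ccccc2n1)Nc1ccccc1F` gives 10700 nM and compound 2 `O=C(CSc1nc(Nc2ccccc2)c2ccccc2n1)Nc1ccccc1Br` gives 18600 nM; the step of a 1.5-fold lower number from compound 1 to compound 3 (0.17 log units; within the scatter) lies within the scatter, whereas a 2.5-fold lower number from compound 2 to compound 3 (0.41 log units; beyond the scatter) is a modest step beyond it, and a 1.7-fold higher number from compound 1 to compound 2 (0.24 log units; within the scatter) changes little. Compound 4 `C=CC(=O)Nc1cccc(NC(=O)CSc2nc(Nc3ccc(C(F)(F)F)cc3)c3ccccc3n2)c1` differs from compound 3 by trifluoromethyl in place of hydrogen on an aromatic carbon. Within the data shown here, none of the measured steps touches this anilino ring; all three concern the amide-side aryl group, so nothing here speaks to the size or direction of this change. The expectation for compound 4 is therefore a step of about a 1.0-fold lower number from compound 3 to compound 4 (0.02 log units; within the scatter) in this assay, that is, no change beyond the scatter, with an estimated 7000 nM and a range of 2500 nM to 20000 nM.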

Compound 4, half-maximal inhibitory concentration: 12100 nM
For compound 4 the middle estimate is 1.7-fold (0.24 log units) below the measured one; the measured number falls inside the stated range.
By their numbers in this assay, from the lowest: compounds 3, 1, 4 and 2 (each within the scatter of the next, the first and the last beyond it).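

Compound 4 is the only compound shown with a change on the anilino ring: in this assay, trifluoromethyl in place of hydrogen, para to a large group, gives a 1.7-fold higher number from compound 3 to compound 4 (0.22 log units; within the scatter) and so stays within the usual scatter. This position therefore accepts these added heavy atoms with no clear change in the number. No measurement shown here explains this result.

Going by these compounds, it remains open whether an amine or a carboxylic acid at this place would shift the number beyond the scatter. On these data alone, it also remains open whether trifluoromethyl would behave the same way alongside the 2-fluorophenyl or 2-bromophenyl amide groups.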